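From a Bromophenyl Ketone to a Methoxyphenyl Amide

The source may hold more compounds than are shown below. What is called first, only, known or untested is meant among the compounds shown, and "the series" means these compounds.

Compound 1 `COc1cc(-c2nnc(SCC(=O)c3ccc(Br)cc3)n2N)cc(OC)c1OC` carries a 4-bromophenyl group on a carbonyl carbon attached to the shared core. In an ADME assay on HEK293 cells (Homo sapiens) for cytotoxicity, read by MTT assay, with a stated time of 48 h (on this read-out higher numbers stand for weaker inhibition and lower numbers for stronger inhibition), compound 1 has no single number to stand on; its entry reads "not determined" (no result reported). Compound 2 `COc1cc(-c2nnc(SCC(=O)c3cccc(Br)c3)n2N)cc(OC)c1OC` is in the same position, its entry in this assay being "not determined" (no result reported). Within the data shown here, the only number in this small set belongs to compound 3 `COc1cc(-c2nnc(SCC(=O)Nc3ccc(C)cc3)n2N)cc(OC)c1OC`, which in this assay gives 79400 nM, a very weak effect on the viability of the cells.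

Compound 4 `COc1cccc(NC(=O)CSc2nnc(-c3cc(OC)c(OC)c(OC)c3)n2N)c1` is the compound still to be tested. Its difference from compound 1 is (3-methoxyphenyl)amino in place of 4-bromophenyl on a carbonyl carbon. Compound 1 has no value, so the step from compound 1 to compound 4 cannot be sized or given a direction. The closest point of reference is compound 3, which, like compound 4, carries an arylamino group on the carbonyl carbon, and I expect compound 4 to land within the usual scatter of that value in this assay rather than move clearly in either direction.

Given that compound 3 gives 79400 nM, compound 4 is expected to give about 80000 nM, with a likely range from 30000 nM to 200000 nM.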

Compound 4, half-maximal inhibitory concentration: 100000 nM
For compound 4 the middle estimate is 1.3-fold (0.10 log units) below the measured one; measured number inside the range.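

This result gives the set its first readable comparison between two compounds that differ in one place. In this assay, putting 3-methoxyphenyl in place of 4-methylphenyl on an amide-type nitrogen gives a 1.3-fold higher number from compound 3 to compound 4 (0.10 log units; within the scatter), so on this read-out the two amides cannot be told apart. For this one pair, then, exchanging one substituted phenyl ring for the other leaves the result within the normal spread of repeated measurements, and nothing available here offers an explanation for it.

The compounds shown leave open whether any group on this amide nitrogen could bring the number clearly down, since the only two amides with values both carry a singly substituted phenyl ring, and a ring bearing a carboxylic acid or an amine, or a longer chain in place of the ring, could behave differently. Also open, as far as these compounds go, is how the 4-bromophenyl ketone of compound 1 and its 3-bromophenyl relative, compound 2, compare with these amides, as neither entry offers a number to set against them.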